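The source may hold more compounds than are shown below. What is called first, only, known or untested is meant among the compounds shown, and "the series" means these compounds.

Within the data shown here, compound 2, with the structure `O=C(/C=C/c1ccc2c(c1)B(O)OC2)c1ccccc1O`, is the weaker of the two compounds measured so far: in a functional assay on SK-OV-3 cells (Homo sapiens) for cytotoxicity, read by MTT assay, with a stated time of 48 h (a lower number here means a stronger inhibitor, a higher number a weaker inhibitor), compound 2 gives 48800 nM, the highest number of the two. Its nearest neighbour is compound 1, with the structure `O=C(/C=C/c1ccc2c(c1)B(O)OC2)c1ccc(F)cc1`, which in this assay gives 1400 nM. Among the measured compounds shown here, the one step seen so far, a 35-fold higher number from compound 1 to compound 2 (1.54 log units; beyond the scatter), shows how much the group on the carbonyl carbon can move the number.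

Compound 3, with the structure `Nc1cccc(C(=O)/C=C/c2ccc3c(c2)B(O)OC3)c1`, differs from compound 2 in one place: 3-aminophenyl in place of 2-hydroxyphenyl on a carbonyl carbon. For the measured compounds named here, no measured step swaps these two particular groups, so the only guide is the size of the single step from compound 1 to compound 2, which shows that this position tolerates large moves. A number lower than that of compound 2 is expected, as compound 2 already stands at the top of the range, but with wide uncertainty. For compound 3 the estimated step is a 4.1-fold lower number from compound 2 to compound 3 (0.61 log units; beyond the scatter). In this assay compound 3 is therefore expected to give about 12000 nM, with a plausible range from 2500 nM to 60000 nM.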

Compound 3, half-maximal inhibitory concentration: 7400 nM
For compound 3 the middle estimate is 1.6-fold (0.21 log units) above the measured one, and the stated range covers the measured number.
By their numbers in this assay, from the lowest: compound 1; then compound 3; then compound 2.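

With a third group on the carbonyl carbon, this assay shows a 6.6-fold lower number from compound 2 to compound 3 (0.82 log units; beyond the scatter) and also a 5.3-fold higher number from compound 1 to compound 3 (0.72 log units; beyond the scatter), so this position gives an intermediate number as well as the two further apart. The change from 2-hydroxyphenyl to 3-aminophenyl leaves the counts of heavy atoms, hydrogen-bond donors and hydrogen-bond acceptors the same, and neither group has a net charge, so a step beyond the scatter can occur here without any change in those counts. This single step changes both the atom, oxygen to nitrogen, and the number in the group's name, so it cannot show which of the two matters.

Nothing available here explains why the numbers differ. Still open, as far as these compounds go, is how 3-hydroxyphenyl or 2-aminophenyl would compare, since either would separate the atom from its place on the ring, and whether a carboxylic acid or a longer chain on this ring would give a number lower than that of compound 1.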